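A few compounds are considered here, and "the series" means these few. Any claim that something is new, unique, unknown or untested is made for them only; others in the source may bear on it.

Measured in a functional assay on SK-OV-3 cells (Homo sapiens) for cytotoxicity, read by MTT assay, with a stated time of 48 h; on this read-out lower numbers stand for stronger inhibition and higher numbers for weaker inhibition:
- compound 1 `COc1cc(-c2ocnc2-c2cc(Br)c(OC)c(OC)c2)ccc1SC`: 1030 nM
- compound 2 `COc1cc(-c2ocnc2-c2cc(OC)c(OC)c(OC)c2)ccc1SC`: 1480 nM
- compound 3 `COc1ccc(-c2ocnc2-c2cc(Br)c(OC)c(OC)c2)cc1SC`: 1160 nM

Compound 2 stands within the scatter of both compound 1 and compound 3, so these numbers give no order among the three.

Compound 4 `COc1cc(-c2ncoc2-c2cc(Br)c(SC)c(OC)c2)cc(OC)c1OC` has not yet been measured in this assay and departs from compound 2 by a single change (bromo in place of hydrogen on an aromatic carbon): bromo in place of hydrogen on an aromatic carbon, ortho to a methylsulfanyl group.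

Going by the values given here, the only measured step involving bromo is a 1.4-fold higher number from compound 1 to compound 2 (0.16 log units; within the scatter), where methoxy takes the place of bromo at a different aromatic carbon, and it stays within the scatter. Among the compounds with values here, no measured pair shows bromo in place of hydrogen, so this guidance is weak and the range is kept wide.

Nothing here points to a step beyond the scatter, and no firm direction is claimed. The expected step is a 1.1-fold lower number from compound 2 to compound 4 (0.06 log units; within the scatter), which is no real change. For compound 4 the estimated value is 1300 nM, with an expected range from 450 nM to 4000 nM.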

Compound 4, half-maximal inhibitory concentration: > 20000 nM
Compound 4: no number, only a limit; the forecaster's own chance of this, stated with the estimate: 5%; middle value at least 15-fold (1.18 log units) away from the limit.
By their numbers in this assay, from the lowest: compounds 1, 3 and 2 (each within the scatter of the next). At a limit, above all of these: compound 4.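

In this assay, bromo in place of hydrogen on an aromatic carbon, ortho to a methylsulfanyl group, produces a large step: an at least 13-fold higher number from compound 2 to compound 4 (1.13 log units; beyond the scatter). The other step among these compounds, at a different aromatic carbon, stays within the scatter, a 1.4-fold higher number from compound 1 to compound 2 (0.16 log units; within the scatter), so this position responds to substitution in a way the earlier compounds did not reveal. For compound 4 the reading is a limit of the assay and not a number, so the true size of the step stays unknown: the limit of > 20000 nM in this assay, at which 1 of the 4 values shown sits.

Whether the step belongs to bromo itself or to any group at this carbon stays open, since the compounds shown include no fluoro, methyl or amine there. Also open, going by these compounds, is whether bromo at this position would act the same way on the core of compound 1 or compound 3.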